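The source may report more compounds than this note shows. Statements on the series, on what has been measured and on what is new or still open speak of the compounds shown alone.

Notes on the series, read throughout in a functional assay on HepG2 cells (Homo sapiens) for antiproliferative activity, read by MTT assay, with a stated time of 72 h; on this read-out lower numbers stand for stronger inhibition and higher numbers for weaker inhibition. Compound 1 (`N#Cc1ccc(/C=N/NC(=O)Nc2ccc(Oc3ccnc4[nH]ccc34)c(F)c2)cc1`) gives 850 nM and compound 2 (`O=C(N/N=C/c1cccc([N+](=O)[O-])c1)Nc1ccc(Oc2ccnc3[nH]ccc23)c(F)c1`) gives 5180 nM on this scale. Going by the values given here, compound 3 (`O=C(N/N=C/c1cccc(Cl)c1Cl)Nc1ccc(Oc2ccnc3[nH]ccc23)c(F)c1`) is reported as "not active" (no number reported) and has no single number, so no step can be sized from it. Compound 4 (`O=C(N/N=C/c1ccc(F)cc1Cl)Nc1ccc(Oc2ccnc3[nH]ccc23)c(F)c1`) differs from compound 3 as follows: 2-chloro-4-fluorophenyl in place of 2,3-dichlorophenyl on a carbon with a double bond to nitrogen with 2-chloro-4-fluorophenyl in place of 2,3-dichlorophenyl on a carbon with a double bond to nitrogen. Among the compounds with values here, the one measured step at that kind of carbon is a 6.1-fold higher number from compound 1 to compound 2 (0.78 log units; beyond the scatter) and it involves other groups, so it offers a scale for change there but no direction for this swap. Relative to compound 3, a modest shift toward stronger inhibition in this assay is expected, of about that size, though a second result without a number remains possible. The expectation therefore lies on the weak side, near compound 2 (5180 nM). The estimated value for compound 4 is 6000 nM with an expected range from 1800 nM to 20000 nM in this estimate.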

Compound 4, half-maximal inhibitory concentration: 1110 nM
The estimate for compound 4 lay 5.4-fold (0.73 log units) above the measured number; the whole stated range lies above it.
By their numbers in this assay, from the lowest: compounds 1 and 4 (each within the scatter of the next); then compound 2.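

In this assay, 2-chloro-4-fluorophenyl in place of 3-nitrophenyl on a carbon with a double bond to nitrogen gives a 4.7-fold lower number from compound 2 to compound 4 (0.67 log units; beyond the scatter) and so recovers the weaker value seen at this place. In place of 4-cyanophenyl, the same group gives a 1.3-fold higher number from compound 1 to compound 4 (0.12 log units; within the scatter) and the two groups cannot be told apart on this read-out. The step from compound 3 cannot be read, as compound 3 has no number, but compound 4 shows that a chlorine-bearing phenyl at this place can give a measured value, so a chlorine on the ring does not by itself go with a "not active" report.

No supporting evidence bears on why these groups differ. As far as these compounds go, how an amine or a carboxylic acid on the phenyl ring at this place would read remains open.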